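Cyclopropylsulfonyl for Methylsulfonyl on a Pyrrolidine Sulfonamide

The compounds below may be only part of what the source reports. "The series", "measured", "known", "first", "only" and "open" are said of these compounds alone.

Measured compounds:
compound 1, `CN1CCN(c2ccc(Nc3ncc4nc(Nc5ccccc5)n([C@H]5CCN(S(C)(=O)=O)C5)c4n3)cc2)CC1`, "not determined" (no result reported)
compound 2, `CN1CCN(c2ccc(Nc3ncc4nc(Nc5ccc(F)cc5)n([C@H]5CCCN(S(=O)(=O)C6CC6)C5)c4n3)cc2)CC1`, 1320 nM
compound 3, `CC(=O)Nc1cccc(-n2c(Nc3ccc(F)cc3)nc3cnc(Nc4ccc(N5CCN(C)CC5)cc4)nc32)c1`, "not determined" (no result reported)

Of the compounds shown here, three sharing one core have been tested in a functional assay on A549 cells (Homo sapiens) for antiproliferative activity, read by MTT assay, with a stated time of 72 h; a higher number here means a weaker inhibitor, a lower number a stronger inhibitor. Compound 1 carries a methylsulfonyl on its pyrrolidine nitrogen and an unsubstituted aniline; in this assay compound 1 gives "not determined" (no result reported). Compound 3 also has no number in this assay, where it gives "not determined" (no result reported). Only compound 2, with a fluorine on the aniline and a cyclopropylsulfonyl on a six-membered ring, has a value: in this assay compound 2 gives 1320 nM. For the measured compounds named here, compound 1 therefore stands without a single number, as does one further entry, and the only fixed point is compound 2.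

The next compound, compound 4, `CN1CCN(c2ccc(Nc3ncc4nc(Nc5ccccc5)n([C@H]5CCN(S(=O)(=O)C6CC6)C5)c4n3)cc2)CC1`, differs from compound 1 in one place: cyclopropyl in place of methyl on a sulfonyl sulfur. Going by the values given here, no measured pair shows this step, so its size is unknown from these data. Such an exchange on a sulfonyl sulfur is expected to move this assay little, likely within the scatter, in either direction.

Taking compound 2 as the only anchor, compound 4 is estimated at 1000 nM in this assay, with a range from 300 nM to 4000 nM.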

Compound 4, half-maximal inhibitory concentration: 540 nM
The estimate for compound 4 lay 1.9-fold (0.27 log units) above the measured number; low and high end bracket the measured number.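

In this assay compound 4 gives 540 nM while compound 1 gives "not determined" (no result reported) and compound 2 differs from compound 4 in more than one place, and no new step can be read. The compounds shown leave open what cyclopropyl in place of methyl on the sulfonyl sulfur does by itself in this assay here. No evidence bearing on this result is available.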